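The source may report more compounds than this note shows. Statements on the series, on what has been measured and on what is new or still open speak of the compounds shown alone.

Three compounds share one core and were tested in a functional assay on CCRF-CEM cells for antagonist activity at C-X-C chemokine receptor type 4 (Homo sapiens), read by calcium flux, with stated times of 25 min and 90 s; a lower number here means a stronger inhibitor, a higher number a weaker inhibitor. Compound 1 `C[C@@H]1CN(c2cccc3c2C[C@H](CN(C)[C@H]2CCCc4cccnc42)NC3)C[C@H](C)N1` gives 61 nM in this assay. Compound 2 `CN(C[C@H]1Cc2c(cccc2N2C[C@@H]3C[C@H]2CN3)CN1)[C@H]1CCCc2cccnc21` gives 146 nM in this assay, and compound 3 `CN(C[C@H]1Cc2c(cccc2N2CCN(C3COC3)CC2)CN1)[C@H]1CCCc2cccnc21` gives 381 nM, the highest number of the three, with a 2.6-fold higher number from compound 2 to compound 3 (0.42 log units; beyond the scatter) and a 6.2-fold higher number from compound 1 to compound 3 (0.80 log units; beyond the scatter). Compound 4 `CN(C[C@H]1Cc2c(cccc2N2CCN(c3cccc(C(F)(F)F)c3)CC2)CN1)[C@H]1CCCc2cccnc21` differs from compound 3 by 3-(trifluoromethyl)phenyl in place of oxetan-3-yl on an amine nitrogen in a ring. Among the compounds with values here, no measured step alters only the group on that amine nitrogen in a ring; the measured steps of a 2.4-fold higher number from compound 1 to compound 2 (0.38 log units; beyond the scatter) and a 2.6-fold higher number from compound 2 to compound 3 (0.42 log units; beyond the scatter) exchanged the whole ring group on the aromatic carbon and gave modest shifts, so a modest step in either direction is plausible here. Compound 4 is expected to give about 300 nM, estimated between 60 nM and 1500 nM, which means a 1.3-fold lower number from compound 3 to compound 4 (0.10 log units; within the scatter) is expected.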

Compound 4, half-maximal inhibitory concentration: > 16700 nM
Compound 4: a limit, no number; the forecaster's own chance of this, stated with the estimate: 5%; middle value at least 55-fold (1.74 log units) away from the limit.
By their numbers in this assay, from the lowest: compound 1; then compound 2; then compound 3. At a limit, above all of these: compound 4.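

Replacing oxetan-3-yl with 3-(trifluoromethyl)phenyl on the ring amine nitrogen gives an at least 43-fold higher number from compound 3 to compound 4 (1.64 log units; beyond the scatter), far larger than any earlier step. Compound 4 therefore yields no number, only a limit: the limit of > 16700 nM in this assay, at which 1 of the 4 values shown sits. The group on this nitrogen can thus decide whether any inhibition is measurable, although the earlier exchanges of the whole ring group shifted the number only modestly.

As far as these compounds go, it remains open whether the aromatic ring or its trifluoromethyl group drives this change. A plain phenyl, a methyl or an acetyl on that nitrogen would help separate these possibilities.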